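The source may hold more compounds than are shown below. What is called first, only, known or untested is meant among the compounds shown, and "the series" means these compounds.

Measured in a functional assay on MDA-MB-231 cells (Homo sapiens) for cytotoxicity, read by MTT assay, with a stated time of 48 h; a lower number here means a stronger inhibitor, a higher number a weaker inhibitor:
compound 1 `O=C(O)CN1C(=O)/C(=C/c2nc3ccccc3n2Cc2ccc([N+](=O)[O-])cc2)SC1=S` gives 7760 nM
compound 2 `O=C(O)CN1C(=O)/C(=C/c2nc3ccccc3n2Cc2ccccc2)SC1=S` gives 1820 nM
compound 3 `Cc1ccc(Cn2c(/C=C3\SC(=S)N(CC(=O)O)C3=O)nc3ccccc32)cc1` gives 1040 nM

Compound 3 stands at the low end of this short series. Even so, a 1.8-fold lower number from compound 2 to compound 3 (0.24 log units; within the scatter) leaves it no clear distance from its nearest neighbour, whereas a 7.5-fold lower number from compound 1 to compound 3 (0.87 log units; beyond the scatter) marks a real gap to the top of the range.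

The next compound, compound 4 `O=C(O)CN1C(=O)/C(=C/c2nc3ccccc3n2Cc2cccc(F)c2)SC1=S`, keeps the shared core and changes only the benzyl group: 3-fluorophenyl in place of 4-methylphenyl on a saturated chain carbon bound to an aromatic nitrogen. Cut one bond further out, this reads 4-methylbenzyl to 3-fluorobenzyl.

Going by the values given here, no measured compound carries fluorine, so the evidence is indirect. Losing the methyl group has little measured weight, as a 1.8-fold lower number from compound 2 to compound 3 (0.24 log units; within the scatter) shows. Among the compounds with values here, the only substituent change that moved the number beyond the scatter involves the nitro compound, with a 4.3-fold lower number from compound 1 to compound 2 (0.63 log units; beyond the scatter) as a modest step. Compound 4 has no nitro group, so the closest reference is compound 2 at 1820 nM, with the high value of compound 1 as a warning that a substituent can raise the number.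

The expectation in this assay is a 1.9-fold higher number from compound 3 to compound 4 (0.28 log units; within the scatter), a small upward move no larger than the scatter.

For compound 4 the estimated value is 2000 nM, with an expected range from 900 nM to 5000 nM.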

Compound 4, half-maximal inhibitory concentration: 22500 nM
Estimate against measurement, compound 4: 11-fold (1.05 log units) below; the whole stated range lies below it.
By their numbers in this assay, from the lowest: compounds 3 and 2 (each within the scatter of the next); then compound 1; then compound 4.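

In this assay adding a fluoro group brings a 12-fold higher number from compound 2 to compound 4 (1.09 log units; beyond the scatter) as a large step, so a benzyl group that had tolerated a methyl group within the scatter can respond strongly to a single substituent. The change from 4-methylbenzyl to 3-fluorobenzyl gives a 22-fold higher number from compound 3 to compound 4 (1.34 log units; beyond the scatter) in the same direction, and a 2.9-fold higher number from compound 1 to compound 4 (0.46 log units; beyond the scatter) shows that this substituent takes the number past even the nitro compound, which makes compound 4 the weakest of the four in this assay. Nothing measured here explains why the step is so large.

Going by these compounds alone, compound 4 is the only compound carrying fluorine, and its 3-fluorophenyl differs from the 4-methylphenyl of compound 3 and the 4-nitrophenyl of compound 1 both in the substituent and in the number in its name, so the two influences cannot be told apart. On these data alone, whether a chloro group, a methoxy group or an amine on the same benzyl ring would stay with compound 2 and compound 3 or rise towards compound 4 remains open.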